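Aryl swap on the carbonyl carbon, compound 3 to compound 4

This account rests on a few compounds, and the source may have more. Where it says the series, first, only, none or still open, it means among the compounds named here.

In an ADME assay on MT4 cells (Homo sapiens) for cytotoxicity, read by MTT assay (a higher number here means that more compound is tolerated, a lower number that less compound is tolerated), compound 1 (`Cc1cccc(C(=O)N(C(=S)OCCN2C(=O)c3ccccc3C2=O)c2ccc(Cl)cc2)c1`) gives 58000 nM, compound 2 (`O=C1c2ccccc2C(=O)N1CCOC(=S)N(C(=O)c1cccc([N+](=O)[O-])c1)c1ccc(Cl)cc1`) gives 18000 nM and compound 3 (`O=C1c2ccccc2C(=O)N1CCOC(=S)N(C(=O)c1c(F)cccc1F)c1ccc(Cl)cc1`) gives 39000 nM. Compound 3 stands in the upper part of these numbers, not separated from the top value. Compound 4 (`O=C1c2ccccc2C(=O)N1CCOC(=S)N(C(=O)c1ccc(Cl)c(Cl)c1)c1ccc(Cl)cc1`) carries 3,4-dichlorophenyl in place of 2,6-difluorophenyl on a carbonyl carbon. Earlier changes in this aryl group moved the number little: a 1.5-fold lower number from compound 1 to compound 3 (0.17 log units; within the scatter), a 2.2-fold higher number from compound 2 to compound 3 (0.34 log units; beyond the scatter) and a 3.2-fold lower number from compound 1 to compound 2 (0.51 log units; beyond the scatter). Within the data shown here, no measured compound carries 3,4-dichlorophenyl at this place, so the basis is indirect. The expected step is small and not beyond the scatter, a 1.3-fold lower number from compound 3 to compound 4 (0.11 log units; within the scatter). The estimate for compound 4 is 30000 nM, with an expected range of 12000 nM to 70000 nM.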

Compound 4, half-maximal cytotoxic concentration: 35000 nM
The estimate for compound 4 lay 1.2-fold (0.07 log units) below the measured number, and the stated range covers the measured number.
By their numbers in this assay, from the lowest: compounds 2, 4, 3 and 1 (each within the scatter of the next, the first and the last beyond it).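

In this assay the carbonyl carbon accepts 3,4-dichlorophenyl in place of 2,6-difluorophenyl with a 1.1-fold lower number from compound 3 to compound 4 (0.05 log units; within the scatter) as the step. The same group gives a 1.9-fold higher number from compound 2 to compound 4 (0.29 log units; within the scatter) against 3-nitrophenyl and a 1.7-fold lower number from compound 1 to compound 4 (0.22 log units; within the scatter) against 3-methylphenyl so compound 4 is separated from neither, although compound 1 and compound 2 stand apart from each other. No available data give a reason for these readings.

Still open, from the compounds shown here alone, is whether the readings stay this close with an amine or a carboxylic acid on the aryl ring, or with a longer chain in place of the aryl group on the carbonyl carbon.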